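From 4-aminocyclohexyl to 6-aminohexyl on the shared core

The source may hold more compounds than are shown below. What is called first, only, known or untested is meant among the compounds shown, and "the series" means these compounds.

Among the compounds with values here, compound 1 (`N[C@H]1CC[C@H](Nc2c(C(=O)NCc3ccc(F)cc3)nc(Br)c3cccnc23)CC1`) is the only compound with a number: in a functional assay on SK-BR-3 cells (Homo sapiens) for cytotoxicity, read by MTT assay, with a stated time of 72 h (a higher number here means a weaker inhibitor, a lower number a stronger inhibitor), compound 1 gives 2000 nM as the sole value available. Compound 2 (`COC(=O)c1nc(Br)c2cccnc2c1N[C@H]1CC[C@H](N)CC1`) is recorded as "not determined" (no result reported) and compound 3 (`N[C@H]1CC[C@H](Nc2c(C(=O)NCc3ccccn3)nc(Br)c3cccnc23)CC1`) is recorded as "not determined" (no result reported), so compound 1 cannot yet be ranked against anything.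

Compound 4 (`NCCCCCCNc1c(C(=O)NCc2ccc(F)cc2)nc(Br)c2cccnc12`) keeps the core of compound 1 and changes one group, with 6-aminohexyl in place of 4-aminocyclohexyl on a nitrogen on an aromatic ring as the counted difference: 6-aminohexyl in place of 4-aminocyclohexyl on a nitrogen on an aromatic ring. The ring of carbon only and the defined stereocentres leave, and no ring enters.

Within the data shown here, the only anchor for an expectation is compound 1 at 2000 nM and no measured step speaks to this change. The estimated 1.3-fold higher number from compound 1 to compound 4 (0.10 log units; within the scatter) in this assay is expected to stay within the usual scatter. For compound 4 the expected value is 2500 nM with an estimated range from 800 nM to 8000 nM as the working figure.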

Compound 4, half-maximal inhibitory concentration: 3000 nM
Compound 4: the middle estimate sits 1.2-fold (0.08 log units) below what was measured; the range from low to high includes it.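

Replacing 4-aminocyclohexyl with 6-aminohexyl on a nitrogen on an aromatic ring gives a 1.5-fold higher number from compound 1 to compound 4 (0.18 log units; within the scatter) in this assay. Within the data shown here, this is the only measured step, and it shows that at this position the six-membered ring of carbon only and the defined stereocentres can give way to an open chain with the same heavy-atom count without a step beyond the scatter. Nothing available explains this outcome.

Open, going by these compounds, is whether this holds when the chain length changes, as with 4-aminobutyl or 8-aminooctyl, or when a hydroxyl group or a carboxylic acid takes the place of the terminal amine. A single step also leaves open whether the same exchange would read alike on a different amide on the shared core.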